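This account rests on a few compounds, and the source may have more. Where it says the series, first, only, none or still open, it means among the compounds named here.

Two amides share a core built on the same threonine-derived backbone. Compound 1 `CCCCCCCCNC(=O)[C@@H](NC(=O)c1ccco1)[C@@H](C)O` gives 124000 nM in a functional assay on SiHa cells (Homo sapiens) for cytotoxicity, read by MTT assay, with a stated time of 48 h; a lower number here means a stronger inhibitor, a higher number a weaker inhibitor. Compound 2 `CCCCCCCCNC(=O)[C@@H](NC(=O)/C=C/c1ccccc1)[C@@H](C)O` gives 41400 nM in this assay, the lowest of the two numbers; the step of a 3.0-fold lower number from compound 1 to compound 2 (0.48 log units; beyond the scatter) arises from 2-phenylethenyl in place of furan-2-yl on a carbonyl carbon. Compound 3 `CCCCCCCCCCCCCCNC(=O)[C@@H](NC(=O)/C=C/c1ccccc1)[C@@H](C)O` differs from compound 2 by hexyl in place of hydrogen on a saturated chain carbon, eight bonds along the chain from an amide-type nitrogen. No measured step touches the chain, so nothing shown bears on this change, and the expected step of a 1.4-fold lower number from compound 2 to compound 3 (0.14 log units; within the scatter) is held near nothing beyond the scatter. Compound 3 is estimated at 30000 nM, within 8000 nM to 120000 nM.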

Compound 3, half-maximal inhibitory concentration: 35800 nM
Estimate against measurement, compound 3: 1.2-fold (0.08 log units) below; the measured number falls inside the stated range.
By their numbers in this assay, from the lowest: compounds 3 and 2 (each within the scatter of the next); then compound 1.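

In this assay, within the data shown here, the first measured step on the chain, hexyl in place of hydrogen, is a 1.2-fold lower number from compound 2 to compound 3 (0.06 log units; within the scatter). With 2-phenylethenyl on the carbonyl carbon, this addition therefore gives no difference beyond the scatter, whereas the earlier step concerned only the group on that carbonyl carbon. No available evidence bears on this result.

Still open, as far as these compounds go, is how a shorter chain, a longer chain or an amine on the chain would read. Also open, from the compounds shown here alone, is whether hexyl gives a similar step with furan-2-yl on the carbonyl carbon.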